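Replacing a Cyclohexyl Ester Group in a Cytotoxicity Series

The source may hold more compounds than are shown below. What is called first, only, known or untested is meant among the compounds shown, and "the series" means these compounds.

Among three compounds measured in an ADME assay on HepG2 2.2.15 cells (Homo sapiens) for cytotoxicity (on this read-out higher numbers stand for lower toxicity in this test and lower numbers for higher toxicity in this test), compound 3 `O=C(OCCc1c(-c2ccccc2Cl)c2cc(Cl)ccc2[nH]c1=O)C1CCCCC1` gives 38000 nM, the lowest number of the set. Compound 1 `CC(C)C(=O)OCCc1c(-c2ccccc2Cl)c2cc(Cl)ccc2[nH]c1=O` gives 62000 nM, and the step of a 1.6-fold lower number from compound 1 to compound 3 (0.21 log units; within the scatter) stays within the scatter. Compound 2 `CCOCC(=O)OCCc1c(-c2ccccc2Cl)c2cc(Cl)ccc2[nH]c1=O` gives 130000 nM, and the step of a 3.4-fold lower number from compound 2 to compound 3 (0.53 log units; beyond the scatter) lies beyond it. Compound 4 `O=C(CN1C(=O)c2ccccc2C1=O)OCCc1c(-c2ccccc2Cl)c2cc(Cl)ccc2[nH]c1=O` differs from compound 3 by a group of 12 heavy atoms (9 carbon, 1 nitrogen, 2 oxygen; one five-membered non-aromatic ring with 1 hetero atom, one six-membered aromatic ring of carbon only) in place of a group of 6 heavy atoms (6 carbon; one six-membered non-aromatic ring of carbon only), on a carbonyl carbon. Both measured steps end at cyclohexyl, so both bear on leaving it: a 1.6-fold lower number from compound 1 to compound 3 (0.21 log units; within the scatter) was small, while a 3.4-fold lower number from compound 2 to compound 3 (0.53 log units; beyond the scatter) was modest. Departing from cyclohexyl toward a group that is not a plain carbon ring, as in compound 2, a modest rise in this assay is expected, possibly not beyond the scatter. Compound 4 is therefore estimated at 65000 nM, with a range from 25000 nM to 160000 nM. The expected step is a 1.7-fold higher number from compound 3 to compound 4 (0.23 log units; within the scatter).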

Compound 4, half-maximal cytotoxic concentration: 960000 nM
Compound 4: the middle estimate sits 15-fold (1.17 log units) below what was measured, outside the stated range (above it).
By their numbers in this assay, from the lowest: compounds 3 and 1 (each within the scatter of the next); then compound 2; then compound 4.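

At this carbonyl carbon, the read-out in this assay proves far more responsive than the earlier esters showed, with a 25-fold higher number from compound 3 to compound 4 (1.40 log units; beyond the scatter) and a 15-fold higher number from compound 1 to compound 4 (1.19 log units; beyond the scatter) both large. Even from the ethoxymethyl ester there is a 7.4-fold higher number from compound 2 to compound 4 (0.87 log units; beyond the scatter) in the same direction, so compound 4 shows lower toxicity in this test than all three compounds with smaller groups. Nothing available explains this rise.

As far as these compounds go, whether it goes with the five-membered ring, the aromatic ring or the 2 hydrogen-bond acceptors stays open. So does what an amine or a carboxylic acid would give on the saturated chain carbon bound to a carbonyl carbon.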